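Removing a Chloro Group from a Peroxide Acid

The source may report more compounds than this note shows. Statements on the series, on what has been measured and on what is new or still open speak of the compounds shown alone.

Measured compounds:
compound 1 `CC(=O)NC1C2CC3CC1CC(C2)C31OO[C@]2(CC[C@@H](c3ccc(OCC(=O)O)cc3)CC2)O1` — 1.8
compound 2 `O=C(O)COc1ccc([C@H]2CC[C@]3(CC2)OOC2(O3)C3CC4CC(C3)CC2C4)cc1Cl` — 3.2

In a physicochemical assay for lipophilicity, read by HPLC, at pH 7.4 (on this read-out higher numbers stand for higher lipophilicity and lower numbers for lower lipophilicity), compound 1 gives 1.8 and compound 2 gives 3.2. Compound 2 stands highest of the two numbers, and its gap to compound 1 lies beyond the scatter. Compound 3 `O=C(O)COc1ccc([C@H]2CC[C@]3(CC2)OOC2(O3)C3CC4CC(C3)CC2C4)cc1` has not been measured; it differs from compound 2 in one place: hydrogen in place of chloro on an aromatic carbon. Going by the values given here, no measured pair here shows this change on its own. A moderate fall in this assay is expected for compound 3, beyond the scatter, as the step of a number 0.60 log units lower from compound 2 to compound 3 (beyond the scatter) states. Compound 3 is estimated at 2.6, within 2.2 to 3.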

Compound 3, distribution coefficient: 2.9
For compound 3 the middle estimate is 0.30 log units below the measured one; the measured number falls inside the stated range.
By their numbers in this assay, from the lowest: compound 1; then compounds 3 and 2 (each within the scatter of the next).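

In this assay, hydrogen in place of chloro on the aromatic carbon ortho to the carboxymethoxy group gives a number 0.30 log units lower from compound 2 to compound 3 (within the scatter), so this change at this position cannot be told apart from the scatter. Hydrogen in place of acetamido on a saturated ring carbon gives a number 1.10 log units higher from compound 1 to compound 3 (beyond the scatter), so the step beyond the scatter here belongs to that carbon and not to the aromatic one. Nothing at hand gives a reason for either step. Open, as far as these compounds go, is whether fluoro or methoxy on that aromatic carbon would also stay within the scatter of compound 2, and how an amine or a hydroxyl on the saturated ring carbon would compare with acetamido.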